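The source may hold more compounds than are shown below. What is called first, only, known or untested is meant among the compounds shown, and "the series" means these compounds.

Compound 1 `Fc1cncc(-c2nc3cc(F)c(Cl)cc3n2C2CC2)c1` is measured in an assay on V79 cells for inhibition of cytochrome P450 11B1, mitochondrial (Homo sapiens), read by HTRF, with a stated time of 1 h (a higher number here means a weaker inhibitor, a lower number a stronger inhibitor), where compound 1 gives 251 nM. Compound 2 `N#Cc1cc2c(cc1F)nc(-c1cncc(F)c1)n2C1CC1` differs from compound 1 by cyano in place of chloro on an aromatic carbon, and in this assay compound 2 gives 225 nM; the step is a 1.1-fold lower number from compound 1 to compound 2 (0.05 log units; within the scatter). Compound 3 `Clc1ccc2nc(-c3cccnc3)n(C3CC3)c2c1` carries a different core, and how its core differs from that of compound 1 is not broken down here; in this assay compound 3 gives 477 nM. Compound 4 `N#Cc1ccc2nc(-c3cccnc3)n(C3CC3)c2c1`, not yet measured, differs from compound 3 by cyano in place of chloro on an aromatic carbon. This is the same kind of change as that from compound 1 to compound 2, though there the place was also ortho to a fluoro group (1 heavy atom), a feature that compound 3 does not share. A similarly small step is expected, because a 1.1-fold lower number from compound 1 to compound 2 (0.05 log units; within the scatter) stayed within the scatter. Compound 4 is therefore expected to give 430 nM in this assay, most likely between 200 nM and 900 nM, an estimated step of a 1.1-fold lower number from compound 3 to compound 4 (0.05 log units; within the scatter).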

Compound 4, half-maximal inhibitory concentration: 374 nM
Compound 4: middle estimate off by 1.1-fold (0.06 log units), on the high side; low and high end bracket the measured number.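

In this assay, cyano in place of chloro on an aromatic carbon gives a 1.3-fold lower number from compound 3 to compound 4 (0.11 log units; within the scatter). Set beside the earlier case, the change carries from one core to the other with no difference beyond the scatter: the same change on two cores in this assay, a 1.1-fold lower number (0.05 log units; within the scatter) from compound 1 to compound 2 and a 1.3-fold lower number (0.11 log units; within the scatter) from compound 3 to compound 4, 1.1-fold (0.06 log units) apart, within the scatter of two such steps. This shows that on these two cores the exchange of chloro for cyano is about neutral in this assay, but two pairs do not show that it would hold on other cores, and they give no reason why the two groups read alike.

The compounds shown leave open whether a different group at that place, such as an amine or a carboxylic acid, would shift the number beyond the scatter.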